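Hydroxylated benzoyl variants on the nitrophenyl hydrazone core

The source may hold more compounds than are shown below. What is called first, only, known or untested is meant among the compounds shown, and "the series" means these compounds.

Compound 1 `CC(/C=N/Nc1ccc([N+](=O)[O-])cc1)=N\NC(=O)c1ccccc1Cl` is measured in a functional assay on cells (Splenocyte, Mus musculus, strain BALB/c) for inhibition, read by scintillation counting and thymidine incorporation, with a stated time of 72 h; a lower number here means a stronger inhibitor, a higher number a weaker inhibitor. In this assay compound 1 gives > 12000 nM, which is a limit of the assay and not a number. Compound 2 `CC(/C=N/Nc1ccc([N+](=O)[O-])cc1)=N\NC(=O)c1ccccc1O` gives 1640 nM in this assay. Compound 3 `CC(/C=N/Nc1ccc([N+](=O)[O-])cc1)=N\NC(=O)c1cccc(C)c1` also sits at a limit in this assay, with > 12000 nM. For the measured compounds named here, the step of an at least 7.3-fold lower number from compound 1 to compound 2 (0.86 log units; beyond the scatter) is the only readable one from compound 1; the step that the two limits leave unreadable from compound 1 to compound 3 cannot be sized because two values sit at the limit of > 12000 nM in this assay, at which 2 of the 3 values shown sit. The step of an at least 7.3-fold higher number from compound 2 to compound 3 (0.86 log units; beyond the scatter) shows that the gain belongs to the hydroxy-bearing ring. Compound 4 `COc1cc(C(=O)N/N=C(C)/C=N/Nc2ccc([N+](=O)[O-])cc2)ccc1O` differs from compound 1 by 4-hydroxy-3-methoxyphenyl in place of 2-chlorophenyl on a carbonyl carbon. Since a hydroxy enters, the step from compound 1 to compound 2 bears on it, and a lower number is expected, though compound 2 carries 2-hydroxyphenyl and compound 4 carries 4-hydroxy-3-methoxyphenyl. Compound 4 is estimated at 4000 nM, with four of five repeats expected between 1000 nM and 15000 nM, meaning an expected step of an at least 3.0-fold lower number from compound 1 to compound 4 (0.47 log units; beyond the scatter).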

Compound 4, half-maximal inhibitory concentration: 5100 nM
Estimate against measurement, compound 4: 1.3-fold (0.11 log units) below; the range from low to high includes it.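

In this assay, the carbonyl carbon also accepts 4-hydroxy-3-methoxyphenyl with measurable activity: replacing 2-chlorophenyl gives an at least 2.3-fold lower number from compound 1 to compound 4 (0.37 log units; beyond the scatter), and replacing 3-methylphenyl gives an at least 2.3-fold lower number from compound 3 to compound 4 (0.37 log units; beyond the scatter). The two hydroxy-bearing rings are not equivalent, with 4-hydroxy-3-methoxyphenyl in place of 2-hydroxyphenyl giving a 3.1-fold higher number from compound 2 to compound 4 (0.49 log units; beyond the scatter). The first two steps start from a limit of the assay and give only a minimum size: the limit of > 12000 nM in this assay, at which 2 of the 4 values shown sit.

Compound 4 differs from compound 2 in both the hydroxy-bearing ring pattern and the added methoxy, so their separate contributions remain unresolved. As far as these compounds go, whether an amine or a carboxylic acid on this ring could stand in for the hydroxy also remains open.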